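Swapping Methoxy for Trifluoromethyl on the Outer Phenyl Ring

A few compounds are considered here, and "the series" means these few. Any claim that something is new, unique, unknown or untested is made for them only; others in the source may bear on it.

Measured compounds:
- compound 1 `CCNc1cc(-c2ccc(NC(=O)Nc3ccc(C(F)(F)F)cc3)cc2C)ccn1`: 54.8%
- compound 2 `CCNc1cc(-c2ccc(NC(=O)Nc3cccc(Cl)c3)cc2F)ccn1`: 72.7%
- compound 3 `CCNc1cc(-c2ccc(NC(=O)Nc3ccc(OC)cc3)cc2F)ccn1`: 47.1%

Of the compounds shown here, three share one core and have been tested in an assay on isolated protein for inhibition of serine/threonine-protein kinase PLK1 (Homo sapiens), read by radiometric assay and 33P incorporation, with a stated time of 40 min, tested at 20 uM, in the presence of a further agent that is not named here; on this read-out higher numbers stand for more inhibition at the one concentration tested (going by the name of the read-out) and lower numbers for less inhibition. Compound 3 stands lowest of the three numbers; compound 1 sits close, within the scatter, while compound 2 lies clearly higher, as shown by a number 25.6 percentage points lower from compound 2 to compound 3 (beyond the scatter). Compound 4 `CCNc1cc(-c2ccc(NC(=O)Nc3ccc(C(F)(F)F)cc3)cc2F)ccn1` has not yet been measured. It differs from compound 3 in one place: trifluoromethyl in place of methoxy on an aromatic carbon.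

Going by the values given here, no measured step covers exactly this change. Among the compounds with values here, the one step that bears on it is a number 25.6 percentage points lower from compound 2 to compound 3 (beyond the scatter), where a methoxy-bearing phenyl replaced a chloro-bearing one and the number fell. Compound 4 carries the same trifluoromethyl group as compound 1, which gives 54.8%, but the central ring of compound 1 differs, so only its value can be noted. Taken together, a rise beyond the scatter is expected, but its size is uncertain. Compound 4 is estimated at 60%, spanning 42% to 78%, meaning an expected step of a number 12.9 percentage points higher from compound 3 to compound 4 (beyond the scatter).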

Compound 4, a percentage reported as inhibition, at one concentration (the size of the read-out at that concentration, not a potency): 55.8%
Estimate against measurement, compound 4: 4.2 percentage points above; the measured number falls inside the stated range.
By their numbers in this assay, from the lowest: compounds 3, 1 and 4 (each within the scatter of the next); then compound 2.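

In this assay, methoxy and trifluoromethyl on the outer ring, para to a large group, cannot be told apart: a number 8.7 percentage points higher from compound 3 to compound 4 (within the scatter) is a step that stays small despite the change of group. Compound 4 also shows that fluoro and methyl on the central ring cannot be separated here, with a number 1 percentage points higher from compound 1 to compound 4 (within the scatter) as the step, while a number 16.9 percentage points lower from compound 2 to compound 4 (beyond the scatter) shows that the 3-chlorophenyl group of compound 2 stands clearly apart from the 4-(trifluoromethyl)phenyl group as well as from the 4-methoxyphenyl group. No measurement shown here explains why these numbers fall as they do.

On these data alone, it remains open whether the higher number of compound 2 comes from the chlorine itself or from where it sits on the ring, which a 4-chlorophenyl group could help to settle. As far as these compounds go, how an amine or a carboxylic acid would behave at this position also remains open.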